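This account rests on a few compounds, and the source may have more. Where it says the series, first, only, none or still open, it means among the compounds named here.

In a functional assay on PC-3 cells (Homo sapiens) for cytotoxicity, read by WST assay, with a stated time of 48 h (on this read-out higher numbers stand for weaker inhibition and lower numbers for stronger inhibition), compound 1 (`N#C/C(=C\c1c[nH]c2cc(F)ccc12)C(=O)c1c[nH]c2cc(F)ccc12`) gives > 50000 nM, which is a limit and not a number. From the compounds shown here alone, compound 2 (`N#C/C(=C\c1c[nH]c2cc(F)ccc12)C(=O)c1c[nH]c2ccccc12`) gives > 50000 nM, also a limit, so its true position is unknown. Among the compounds with values here, the series so far shows (the limit of > 50000 nM in this assay, at which 2 of the 2 values shown sit). Compound 3 (`COc1ccc2[nH]cc(C(=O)/C(C#N)=C/c3c[nH]c4cc(F)ccc34)c2c1`) differs from compound 2 by methoxy in place of hydrogen on an aromatic carbon. Within the data shown here, the only measured step bearing on this is a step that the two limits leave unreadable from compound 1 to compound 2, and it concerns a different change. No step beyond the scatter is therefore expected in this assay, and no direction can be assigned. The expected step is a number no higher from compound 2 to compound 3 (the limit leaves the size open). For compound 3 the estimated value is 50000 nM, with an expected range of 15000 nM to 100000 nM.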

Compound 3, half-maximal inhibitory concentration: > 50000 nM
Compound 3 was reported as a limit (the forecaster's own chance of this, stated with the estimate: 70%); the middle value sits exactly at the limit.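

The step between compound 2 and compound 3 cannot be read in this assay, as both results are limits and not numbers. The compounds shown leave open whether methoxy in place of hydrogen changes anything, with the whole series resting at one point: the limit of > 50000 nM in this assay, at which 3 of the 3 values shown sit.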